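Estimating Half-Life for a Dimethylaminoethyl Propyl Amine Analogue

This account rests on a few compounds, and the source may have more. Where it says the series, first, only, none or still open, it means among the compounds named here.

Measured compounds in an in vitro ADME assay on microsomes (Rattus norvegicus) for metabolic stability; on this read-out higher numbers stand for a longer-lived compound and lower numbers for a shorter-lived compound:
Compound 1, `CCCN(CC1CC1)c1nc(CC)c(-c2ccc(Cl)cc2Cl)nc1CC`, gives 0.07 h.
Compound 2, `CCc1nc(N(CC2CC2)CC2CC2)c(CC)nc1-c1ccc(Cl)cc1Cl`, gives only a limit of the assay, < 0.0167 h.
Compound 3, `CCc1nc(-c2ccc(Cl)cc2Cl)c(CC)nc1NC(COC)COC`, gives 0.0417 h.

Among the two actual numbers, compound 3 holds the lower one, but its nearest neighbour is compound 1 and the gap a 1.7-fold lower number from compound 1 to compound 3 (0.22 log units; within the scatter) lies within the scatter, so the two cannot be ordered. Compound 2 sits at the limit of < 0.0167 h in this assay, at which 1 of the 3 values shown sits, so no number is known for it.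

The unmeasured compound 4, `CCCN(CCN(C)C)c1nc(CC)c(-c2ccc(Cl)cc2Cl)nc1CC`, differs from compound 3 in one place: (2-(dimethylamino)ethyl)(propyl)amino in place of (2-methoxy-1-(methoxymethyl)ethyl)amino on an aromatic carbon. This brings back a propyl chain on the nitrogen, as found in compound 1, paired now with a (2-(dimethylamino)ethyl) chain.

Among the measured compounds shown here, two measured steps bear on the change. The step of a 1.7-fold lower number from compound 1 to compound 3 (0.22 log units; within the scatter) shows that exchanging a two-chain amino group for the dimethoxy amine moved the number only within the scatter. The step of an at least 2.4-fold higher number from compound 2 to compound 3 (0.39 log units; beyond the scatter) shows a beyond-scatter rise when leaving the bis(cyclopropylmethyl)amino compound, and an at least 4.1-fold lower number from compound 1 to compound 2 (0.62 log units; beyond the scatter) shows that cyclopropyl in place of ethyl on that chain lowered the number. Compound 4 carries propyl, not cyclopropyl, so a step of about the size a 1.4-fold higher number from compound 3 to compound 4 (0.16 log units; within the scatter) is expected, within the scatter. Compound 4 is therefore estimated at 0.06 h, between 0.02 h and 0.18 h.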

Compound 4, half-life: < 0.0167 h
Compound 4 gave a limit, no number (the forecaster's own chance of this, stated with the estimate: 15%); middle value at least 3.5-fold (0.55 log units) from the limit.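

At this aromatic carbon, the only drop beyond the scatter so far had come with bis(cyclopropylmethyl)amino, but a group without any cyclopropyl can also shorten the half-life in this assay, as shown by an at least 2.4-fold lower number from compound 3 to compound 4 (0.39 log units; beyond the scatter). Keeping the propyl chain of compound 1 did not preserve its number either: changing the other chain on that nitrogen, with (dimethylamino)methyl in place of cyclopropyl on the saturated chain carbon, gave an at least 4.1-fold lower number from compound 1 to compound 4 (0.62 log units; beyond the scatter), so the outcome depends on the second chain as well as on the propyl. Compound 4 gives only a limit, and the step from compound 2 to compound 4 cannot be read, which leaves compound 4 at the same edge of the scale as compound 2: the limit of < 0.0167 h in this assay, at which 2 of the 4 values shown sit.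

As far as these compounds go, how compound 2 and compound 4 rank against each other remains open, since neither has an actual number. It is also unclear whether the drop belongs to the dimethylamino nitrogen or simply to the length of the chain, a question that a plain butyl chain or a hydroxyl group at the end of the ethyl chain would help to settle.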